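This account rests on a few compounds, and the source may have more. Where it says the series, first, only, none or still open, it means among the compounds named here.

Measured compounds:
compound 2 `O=C(O)/C=C/c1ccncc1-c1ccc2ccccc2c1` — 5 nM
compound 3 `CN1CCN(C(=O)/C=C/c2ccncc2-c2ccc(F)cc2)CC1` — 1210 nM
compound 1 `O=C(COc1ccncc1-c1ccc2ccccc2c1)N1CCOCC1` — "not determined" (no result reported)

The read-out throughout is an assay on a protein complex for inhibition of CDK8/Cyclin C (Homo sapiens), with a stated time of 1 h; a higher number here means a weaker inhibitor, a lower number a stronger inhibitor. For the measured compounds named here, compound 2 has the lowest of the two numbers: compound 3 gives 1210 nM, a markedly higher number than compound 2, beyond the scatter, but the two differ in more than one place, so no single-point step is available between them. Compound 1 carries no result in this assay.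

Compound 4 `O=C(/C=C/c1ccncc1-c1ccc2ccccc2c1)NC1CC1` is the next compound to be tested. It differs from compound 2 in one place: cyclopropylamino in place of hydroxy on a carbonyl carbon. Going by the values given here, no pair among the measured compounds isolates this kind of change, so the expected size of the step rests on the general picture only: compound 3, the one amide with a number, sits far above the acid compound 2, though its aromatic substituent differs as well.

The expectation for compound 4 is therefore a number somewhat higher than that of compound 2, a modest rise rather than a collapse: compound 4 is estimated at 30 nM, with a plausible range of 5 nM to 200 nM. The step this estimate implies is a 6.0-fold higher number from compound 2 to compound 4 (0.78 log units; beyond the scatter).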

Compound 4, half-maximal inhibitory concentration: 40.1 nM
The estimate for compound 4 lay 1.3-fold (0.13 log units) below the measured number; the range from low to high includes it.
By their numbers in this assay, from the lowest: compound 2; then compound 4; then compound 3.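

In this assay, for the compounds shown here, this is the first comparison that isolates a single change: cyclopropylamino in place of hydroxy on a carbonyl carbon gives an 8.0-fold higher number from compound 2 to compound 4 (0.90 log units; beyond the scatter), a modest step. The earlier compounds shown here differed in more than one place, so they could not show what this exchange alone does; in this one pair, inhibition survives the move from carboxy to cyclopropylcarbamoyl on the shared core, at a measurable but limited cost. No accompanying data bear on why the step has this size.

As far as these compounds go, it remains open whether the step belongs to the amide as such or to the cyclopropyl ring, a question that a plain amino group, a methylamino group or an isopropylamino group on the same carbonyl carbon would address on the core of compound 2. Also open, from the compounds shown here alone, is where a methyl ester on that carbonyl carbon would fall relative to the acid and the cyclopropyl amide, and whether a longer chain between the core and the carbonyl would change the size of the same exchange.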